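Cytotoxicity notes: nitro in place of chloro

This account rests on a few compounds, and the source may have more. Where it says the series, first, only, none or still open, it means among the compounds named here.

Measured so far in an ADME assay on BJ cells (Homo sapiens) for cytotoxicity, read by CellTiter-Glo and resazurin assay, with a stated time of 72 h; on this read-out higher numbers stand for an effect only at larger amounts of compound and lower numbers for an effect already at smaller amounts:
compound 1 `CCOC(=O)CCCCCOc1cccc(CN(C(=O)c2ccc(-c3cccc(-c4nnc(C)o4)c3)cc2)C(C)C)c1` gives only the assay limit > 26000 nM
compound 2 `CCOC(=O)CCCCCOc1cccc(CN(C(=O)c2ccc(-c3cccc(Cl)c3)cc2)C(C)C)c1` gives only the assay limit > 18400 nM

Compound 1 reaches no readable number in this assay; its value is a limit. Compound 2 likewise reaches no number and stands only at a limit. Within the data shown here, the one step between them, a step that the two limits leave unreadable from compound 1 to compound 2, therefore cannot be sized, because the limit of > 18400 nM in this assay, at which 1 of the 2 values shown sits, and the limit of > 26000 nM in this assay, at which 1 of the 2 values shown sits, are both limits and no gap between two limits can be read.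

Compound 3 `CCOC(=O)CCCCCOc1cccc(CN(C(=O)c2ccc(-c3cccc([N+](=O)[O-])c3)cc2)C(C)C)c1` carries the change (nitro in place of chloro on an aromatic carbon). Among the measured compounds shown here, the only measured step that bears on it is the unreadable one from compound 1 to compound 2, so no direction and no size can be borrowed from it. With both measured compounds at limits in this assay, the most likely outcome for compound 3 is a further limit rather than a number, and the step that the limit leaves unreadable from compound 2 to compound 3 is expected to stay within the scatter. Compound 3 is estimated at 30000 nM in this assay, with a range from 10000 nM to 100000 nM.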

Compound 3, half-maximal effective concentration: < 1.3 nM
Compound 3: only a limit was reported; the forecaster's own chance of this, stated with the estimate: 80%; middle value at least 23000-fold (4.36 log units) away from the limit.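

In this assay compound 3 gives < 1.3 nM, which is a limit of the assay and not a number. Nitro in place of chloro on this aromatic carbon gives an at least 14000-fold lower number from compound 2 to compound 3 (4.15 log units; beyond the scatter), and nitro in place of 5-methyl-1,3,4-oxadiazol-2-yl at the same place gives an at least 20000-fold lower number from compound 1 to compound 3 (4.30 log units; beyond the scatter), so the group at this place, meta to a large group, can move the read-out from no effect within the tested range to an effect at very small amounts of compound. The earlier pair could not show this: the step between compound 1 and compound 2 cannot be read, and both steps to compound 3 are large and beyond the scatter, in the same direction.

Still open is whether this effect belongs to nitro alone or would also appear with an amine or a nitrile on the same aromatic carbon, since the compounds shown offer only three groups there and a single one with an effect. Also open, as far as these compounds go, is the true size of both steps, and whether nitro gives the same result with a different chain on the rest of the core.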